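From pentyl to cyclohex-3-en-1-yl on a carbonyl carbon

The source may hold more compounds than are shown below. What is called first, only, known or untested is meant among the compounds shown, and "the series" means these compounds.

Three compounds have been measured in an assay on cells for agonist activity at ecdysone receptor (Bombyx mori), read by a luciferase reporter, with a stated time of 24 h; a lower number here means that less compound is needed, a higher number that more compound is needed for the effect:
- compound 1 `Cc1cccc(C(=O)NN(C(=O)c2ccccc2Cl)C(C)(C)C)c1C` gives 20 nM
- compound 2 `CCOc1ccccc1C(=O)N(NC(=O)c1ccc(CC)cc1)C(C)(C)C` gives 2880 nM
- compound 3 `CCCCCC(=O)N(NC(=O)c1ccc(CC)cc1)C(C)(C)C` gives 2820 nM

Among these three numbers compound 3 sits near the top, close to compound 2, and far from compound 1, whose value of 20 nM stands well apart. Compound 3 itself gives 2820 nM. Compound 4 `CCc1ccc(C(=O)NN(C(=O)C2CC=CCC2)C(C)(C)C)cc1` has not yet been measured. It differs from compound 3 in one place: cyclohex-3-en-1-yl in place of pentyl on a carbonyl carbon. All other parts, including the tert-butyl on the nitrogen and the ethyl-substituted benzoyl, stay as they are.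

Among the compounds with values here, the only measured step that touches this position is a 1.0-fold lower number from compound 2 to compound 3 (0.01 log units; within the scatter), where a quite different group, an aromatic ring with an ethoxy, was exchanged for the pentyl chain without any change beyond the scatter. This suggests that this carbonyl position tolerates exchanges of groups of similar size without a large shift, though one step is thin evidence. A six-membered non-aromatic ring with one double bond is close in size to the pentyl chain it replaces, so for compound 4 a step of about a 1.4-fold lower number from compound 3 to compound 4 (0.15 log units; within the scatter) is expected, within or only slightly beyond the scatter. Compound 4 is therefore estimated at 2000 nM, with a range from 500 nM to 8000 nM.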

Compound 4, half-maximal effective concentration: 1000 nM
Estimate against measurement, compound 4: 2.0-fold (0.30 log units) above; the measured number falls inside the stated range.
By their numbers in this assay, from the lowest: compound 1; then compound 4; then compounds 3 and 2 (each within the scatter of the next).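

Within the data shown here, until now the only step at this carbonyl carbon lay within the scatter, so the position could have seemed indifferent to the group it carries. In this assay cyclohex-3-en-1-yl now gives a modest step beyond the scatter against pentyl (a 2.8-fold lower number from compound 3 to compound 4 (0.45 log units; beyond the scatter)) and also against 2-ethoxyphenyl (a 2.9-fold lower number from compound 2 to compound 4 (0.46 log units; beyond the scatter)), so the group here can move the number, and this non-aromatic ring gives a lower number than either the open chain or the substituted aromatic ring. Nothing available explains this gain.

The compounds shown do not separate the contribution of the ring from that of its double bond, and a plain cyclohexyl group, which has the ring without the double bond, would draw that line. They also leave open how much room this position allows for change, since a smaller ring such as cyclopentyl, a longer chain such as heptyl, or a ring carrying an amine or a carboxylic acid could each shift the number in either direction.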